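Side-chain variation on a shared core in tail flick

A few compounds are considered here, and "the series" means these few. Any claim that something is new, unique, unknown or untested is made for them only; others in the source may bear on it.

Measured compounds:
Compound 1, `C[C@H](NC(=O)CN(c1nc(Cl)nc2[nH]cnc12)C1CC1)C(=O)OCc1ccccc1`, in a functional assay on the whole organism (Tail, strain ICR) with Mus musculus as the target, in the tail flick test, with a stated time of 90 min, at a dose of 25 umol/kg by the oral route (on this read-out lower numbers stand for a weaker effect and higher numbers for a stronger effect at the one dose given), compound 1 gives 44.2%.
Compound 2, `CC[C@H](C)[C@H](NC(=O)CN(c1nc(Cl)nc2[nH]cnc12)C1CC1)C(=O)OCc1ccccc1`, in this assay compound 2 gives 36.3%.
Compound 3, `CSCC[C@H](NC(=O)CN(c1nc(Cl)nc2[nH]cnc12)C1CC1)C(=O)OCc1ccccc1`, in this assay compound 3 gives 44.6%.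

All three compounds share one core and differ only in the group on the saturated chain carbon bound to an amide-type nitrogen and a carbonyl carbon. Compound 3 holds the highest of the three numbers in this assay, but the gaps to its neighbours are small: a number 0.4 percentage points higher from compound 1 to compound 3 (within the scatter) and a number 8.3 percentage points higher from compound 2 to compound 3 (within the scatter), both within the scatter, as is a number 7.9 percentage points lower from compound 1 to compound 2 (within the scatter). Nothing in these three steps separates the compounds in a reliable way.

Compound 4, `NC(=O)CC[C@H](NC(=O)CN(c1nc(Cl)nc2[nH]cnc12)C1CC1)C(=O)OCc1ccccc1`, is not yet measured. It differs from compound 3 as follows: carbamoyl in place of methylsulfanyl on a saturated chain carbon, three bonds along the chain from an amide-type nitrogen and a carbonyl carbon. Among the measured compounds shown here, no measured step exchanges a methylsulfanyl for a carbamoyl, so the bearing steps are only those that vary the same side chain, and all of them stayed within the scatter. On that basis the step from compound 3 to compound 4 in this assay is expected to be a number 4.6 percentage points lower from compound 3 to compound 4 (within the scatter), none beyond the scatter. For compound 4 the estimated value in this assay is 40%, with a range from 25% to 55%.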

Compound 4, a percentage reported as activity, at one dose (the size of the read-out at that dose, not a potency): 42.8%
Beside the measured number, compound 4's estimate is 2.8 percentage points below it, within the range that was stated.
By their numbers in this assay, from the lowest: compounds 2, 4, 1 and 3 (each within the scatter of the next).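

In this assay, carbamoyl in place of methylsulfanyl adds a hydrogen-bond donor at the end of the side chain, and the step reads as (a number 1.8 percentage points lower from compound 3 to compound 4 (within the scatter)), so this exchange does not separate the two compounds. Among the compounds shown here, the same holds against the other side chains, with 2-carbamoylethyl in place of sec-butyl (a number 6.5 percentage points higher from compound 2 to compound 4 (within the scatter)) and carbamoylmethyl in place of hydrogen (a number 1.4 percentage points lower from compound 1 to compound 4 (within the scatter)), which means that a side chain ending in carbamoyl now joins the methyl, sec-butyl and 2-(methylsulfanyl)ethyl groups in a set that no step divides at this position. Nothing available explains why these exchanges leave the read-out within the scatter.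

As far as these compounds go, whether a carboxylic acid or an amine at the end of this side chain, a longer chain, or a benzyl group on the same saturated chain carbon would give a step beyond the scatter remains open. The compounds shown also leave open whether their numbers would stay this close at another dose or another time point, as each is read at a single dose and a single stated time.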